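Ring Contraction and a Methyl on the Amide Side

The compounds below may be only part of what the source reports. "The series", "measured", "known", "first", "only" and "open" are said of these compounds alone.

Three compounds share one core, and all three meet the same ceiling. Compound 1 `O=C(C1CCCCC1)N1CC(c2nc(-c3cccc(F)c3)no2)C1` in an assay on HEK293 cells for negative allosteric modulation of metabotropic glutamate receptor 5 (Homo sapiens), read by FLIPR (a lower number here means a stronger inhibitor, a higher number a weaker inhibitor), gives > 10000 nM, a limit of the assay and not a number. Compound 2 `CC1CCCCC1C(=O)N1CC(c2nc(-c3cccc(F)c3)no2)C1` likewise gives > 10000 nM, again a limit. Compound 3 `O=C(N1CCCCC1)N1CC(c2nc(-c3cccc(Cl)c3)no2)C1` gives > 10000 nM, also a limit. For the measured compounds named here, the one measured step, a step that the two limits leave unreadable from compound 1 to compound 2, therefore cannot be read, since both of its ends sit at the limit of > 10000 nM in this assay, at which 3 of the 3 values shown sit. Compound 3 thus stands nowhere in particular among the numbers shown: it sits with the other two at the limit, and on this evidence no compound can be called weaker or stronger than another. Compounds 1 and 3 each sit at the limit, and no step between them is shown.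

Compound 4 `CC1CCN(C(=O)N2CC(c3nc(-c4cccc(Cl)c4)no3)C2)C1` differs from compound 3 by 3-methylpyrrolidin-1-yl in place of piperidin-1-yl on a carbonyl carbon. Going by the values given here, no measured step bears on this change: the only step available is unreadable. With every value at the limit there is nothing to anchor a direction. Compound 4 is expected to remain at the limit, a step that the limit leaves unreadable from compound 3 to compound 4 of no readable size. The estimated value for compound 4 in this assay is 20000 nM, expected to lie between 5000 nM and 80000 nM.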

Compound 4, half-maximal inhibitory concentration: > 10000 nM
Compound 4 was reported as a limit; the forecaster's own chance of this, stated with the estimate: 75%; the middle value lies beyond the limit too.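

No new step can be read between compound 3 and compound 4, since in this assay both stand at a limit and neither gives a number: the limit of > 10000 nM in this assay, at which 4 of the 4 values shown sit.

The compounds shown leave open whether any group on the carbonyl carbon of the shared core can bring a value inside the measurable range, and which change would do so.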